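The source may hold more compounds than are shown below. What is called first, only, known or untested is meant among the compounds shown, and "the series" means these compounds.

Values in an ADME assay on HepG2 2.2.15 cells (Homo sapiens) for cytotoxicity (a lower number here means that less compound is tolerated, a higher number that more compound is tolerated), for the compounds measured so far
compound 1 `O=c1[nH]c2ccc(Cl)cc2c(-c2ccccc2Cl)c1CCO` gives 380000 nM
compound 2 `CC(=O)OCC(=O)OCCc1c(-c2ccccc2Cl)c2cc(Cl)ccc2[nH]c1=O` gives 100000 nM
compound 3 `O=C(OCCc1c(-c2ccccc2Cl)c2cc(Cl)ccc2[nH]c1=O)c1ccc([N+](=O)[O-])cc1` gives 1600000 nM

Compound 3 holds the highest of these numbers (1600000 nM) and lies clearly above the other two. The next change concerns the group on its carbonyl: compound 4 `O=C(OCCc1c(-c2ccccc2Cl)c2cc(Cl)ccc2[nH]c1=O)c1cccnc1` has pyridin-3-yl in place of 4-nitrophenyl on a carbonyl carbon. For the measured compounds named here, no measured step makes this exact swap, so the nearest evidence comes from what was placed on the oxygen of compound 1. Adding (acetoxymethyl)carbonyl there gave a 3.8-fold lower number from compound 1 to compound 2 (0.58 log units; beyond the scatter), while adding (4-nitrophenyl)carbonyl gave a 4.2-fold higher number from compound 1 to compound 3 (0.62 log units; beyond the scatter). Exchanging the groups on the carbonyl carbon gave the largest step, a 16-fold higher number from compound 2 to compound 3 (1.20 log units; beyond the scatter), so this position can move the number a long way in either direction. Only compound 3, the one carrying 4-nitrophenyl, stands above compound 1. With that group gone, a number nearer those of compound 1 and compound 2 seems likelier, although three compounds are thin support. The expected change is a modest drop, estimated as a 4.0-fold lower number from compound 3 to compound 4 (0.60 log units; beyond the scatter) in this reading. Compound 4 is estimated at 400000 nM and is expected to fall between 120000 nM and 1300000 nM on measurement.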

Compound 4, half-maximal cytotoxic concentration: 170000 nM
For compound 4 the middle estimate is 2.4-fold (0.37 log units) above the measured one; low and high end bracket the measured number.
By their numbers in this assay, from the lowest: compounds 2 and 4 (each within the scatter of the next); then compound 1; then compound 3.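

Not every aromatic ring on this carbonyl carbon goes with a high number: in this assay pyridin-3-yl in place of 4-nitrophenyl gives a 9.4-fold lower number from compound 3 to compound 4 (0.97 log units; beyond the scatter) and takes away the lead that compound 3 held. The same position also tolerates very different groups with no readable difference, as pyridin-3-yl in place of acetoxymethyl gives a 1.7-fold higher number from compound 2 to compound 4 (0.23 log units; within the scatter) and that step lies within the usual scatter. Placing (pyridin-3-yl)carbonyl on the oxygen of compound 1 gives a 2.2-fold lower number from compound 1 to compound 4 (0.35 log units; beyond the scatter) and so moves the number the same way as (acetoxymethyl)carbonyl did, which leaves compound 3 as the only one of the three esters above compound 1. Nothing measured here explains why these groups on the carbonyl carbon part ways.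

Going by these compounds, it remains open whether the high number of compound 3 goes with the nitro group or with the ring of carbon only, a question that a plain phenyl on the carbonyl carbon would help to settle. On these data alone, how an amine or a carboxylic acid on that ring would read in this assay also stays unknown.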